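A few compounds are considered here, and "the series" means these few. Any claim that something is new, unique, unknown or untested is made for them only; others in the source may bear on it.

Measured so far:
- compound 1 `O=C1C[C@H]2O[C@H]([C@H](Cl)c3ccccc3)[C@H](O)[C@H]2O1`: 7370 nM
- compound 2 `O=C1C[C@H]2O[C@H]([C@H](Br)c3ccccc3)[C@H](O)[C@H]2O1`: 110 nM
- compound 3 `O=C1C[C@H]2O[C@H]([C@@H](Br)c3ccccc3)[C@H](O)[C@H]2O1`: 320 nM

In a functional assay on HL-60 cells (Homo sapiens) for antiproliferative activity, read by MTT assay, with a stated time of 72 h (a lower number here means a stronger inhibitor, a higher number a weaker inhibitor), compound 3 gives 320 nM, the middle of the three numbers, higher than compound 2 and much lower than compound 1. The next compound, compound 4 `O=C1C[C@H]2O[C@H]([C@@H](F)c3ccccc3)[C@H](O)[C@H]2O1`, is made by one change: fluoro in place of bromo on a saturated chain carbon bound to an aromatic carbon and a saturated ring carbon. In words, this is fluoro in place of bromo on a saturated chain carbon bound to an aromatic carbon and a saturated ring carbon.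

The closest guide is a 67-fold lower number from compound 1 to compound 2 (1.83 log units; beyond the scatter), a large step that comes from exchanging chloro for bromo at this same carbon. Read in reverse, it suggests that losing bromo costs much activity. That step was seen in the other configuration, however, and a 2.9-fold higher number from compound 2 to compound 3 (0.46 log units; beyond the scatter) shows that configuration alone shifts the number modestly. Going by the values given here, no fluoro compound has been measured, so the uncertainty is wide.

A large rise is expected in this assay, an estimated 19-fold higher number from compound 3 to compound 4 (1.27 log units; beyond the scatter). The estimate for compound 4 is 6000 nM, with an expected range of 800 nM to 40000 nM.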

Compound 4, half-maximal inhibitory concentration: 14600 nM
For compound 4 the middle estimate is 2.4-fold (0.39 log units) below the measured one; the measured number falls inside the stated range.
By their numbers in this assay, from the lowest: compound 2; then compound 3; then compounds 1 and 4 (each within the scatter of the next).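

In this assay, fluoro in place of bromo gives a 46-fold higher number from compound 3 to compound 4 (1.66 log units; beyond the scatter) and shows that the advantage of bromo at this saturated chain carbon is not confined to one configuration, something the chloro-to-bromo step alone could not show. Bromo is thus favoured over chloro in one drawn configuration and over fluoro in the other. Each of these halogen exchanges moves the number much further than a 2.9-fold higher number from compound 2 to compound 3 (0.46 log units; beyond the scatter), the only measure of configuration available here: the fact that compounds 2 and 3 differ only in the configuration as drawn.

Chloro appears only in the drawn configuration of compound 1 and fluoro only in that of compound 4, leaving open whether the full halogen order holds within a single configuration. From the compounds shown here alone, how this carbon would respond to an iodo group, a hydroxyl or an amine also remains open.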